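Fluoro variant of compound 3 in the same assay

This account rests on a few compounds, and the source may have more. Where it says the series, first, only, none or still open, it means among the compounds named here.

Measured so far in an ADME assay on MCF-10A cells (Homo sapiens) for inhibition, read by MTT assay, with a stated time of 48 h, tested at 2 uM; a lower number here means less inhibition, a higher number more inhibition at the concentration tested (going by the name of the read-out):
compound 1 `Cc1noc(C)c1-c1ccc2c(c1)C(c1ccccc1)N(Cc1ncc(-c3ccccc3)o1)C(=O)N2C` gives 3.7%
compound 2 `Cc1nc(-c2ccccc2)sc1CN1C(=O)N(C)c2ccc(-c3c(C)noc3C)cc2C1c1ccccc1` gives 4.9%
compound 3 `Cc1noc(C)c1-c1ccc2c(c1)C(c1ccccc1)N(Cc1nc(-c3ccccc3)cs1)C(=O)N2C` gives 2.7%

Compound 3 holds the lowest of the three numbers, yet all three lie within the scatter of one another: a number 1 percentage points lower from compound 1 to compound 3 (within the scatter) and a number 2.2 percentage points lower from compound 2 to compound 3 (within the scatter) are both small, as is a number 1.2 percentage points higher from compound 1 to compound 2 (within the scatter). No ordering can be drawn from them.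

Compound 4 `Cc1noc(C)c1-c1ccc2c(c1)C(c1ccccc1)N(Cc1nc(-c3ccc(F)cc3)cs1)C(=O)N2C` differs from compound 3 by fluoro in place of hydrogen on an aromatic carbon. Going by the values given here, none of the measured steps touches the phenyl ring on the thiazole; each of them swaps the whole heterocycle, so no direct precedent exists. The three flat numbers suggest compound 4 is expected to stay in the same low band, with a number 0.8 percentage points higher from compound 3 to compound 4 (within the scatter) expected to remain within the scatter. For compound 4 the estimate is 3.5%, with a range from -3% to 11%.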

Compound 4, a percentage reported as inhibition, at one concentration (the size of the read-out at that concentration, not a potency): 8.5%
Compound 4: middle estimate off by 5 percentage points, on the low side; the range from low to high includes it.
By their numbers in this assay, from the lowest: compounds 3, 1, 2 and 4 (each within the scatter of the next).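

In this assay, going by these compounds alone, fluoro in place of hydrogen on the phenyl ring of the thiazole, para to a large group, gives a number 5.8 percentage points higher from compound 3 to compound 4 (within the scatter), the first reading at this position, and it shows no step beyond the scatter. Compared across the heterocycle swaps, the fluorinated ring gives a number 3.6 percentage points higher from compound 2 to compound 4 (within the scatter) and a number 4.8 percentage points higher from compound 1 to compound 4 (within the scatter), so compound 4 separates from none of the other three. No evidence bears on the result.

Fluoro is the only substituent on this phenyl ring among these compounds, so the position rests on one step. From the compounds shown here alone, whether methoxy, an amine or a carboxylic acid at the same place would give a step beyond the scatter remains open.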